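The source may report more compounds than this note shows. Statements on the series, on what has been measured and on what is new or still open speak of the compounds shown alone.

Working notes on the series. Compound 1 `C=C(C)[C@@H]1CC=C(Cn2cc(COc3cc(C4NC(=O)NC(C)=C4C(C)=O)ccc3OC)nn2)CC1` and compound 2 `C=C(C)[C@@H]1CC=C(Cn2cc(COc3ccc(C4NC(=O)NC(C)=C4C(C)=O)cc3OC)nn2)CC1` carry the same core on differently substituted aromatic rings. In a functional assay on 786-0 cells (Homo sapiens) for inhibition, read by sulforhodamine B assay, with a stated time of 48 h (on this read-out higher numbers stand for weaker inhibition of growth and lower numbers for stronger inhibition of growth), compound 2 gives 88100 nM. For compound 1 the result in this assay is only a limit, > 100000 nM. Compound 3 `C=C(C)[C@@H]1CC=C(Cn2cc(COc3cccc(C4NC(=O)NC5=C4C(=O)CC(C)(C)C5)c3)nn2)CC1` carries a different core on an aromatic ring without the methoxy group. For compound 3 the result in this assay is again only a limit, > 100000 nM. Going by the values given here, compound 3 therefore stands at the limit of > 100000 nM in this assay, at which 2 of the 3 values shown sit, and no numbered value places it within the range of the assay; the only numbered value among the three belongs to compound 2.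

Compound 4 `C=C(C)[C@@H]1CC=C(Cn2cc(COc3cc(C4NC(=O)NC5=C4C(=O)CC(C)(C)C5)ccc3OC)nn2)CC1` is the next member to be measured. It differs from compound 3 in one place: methoxy in place of hydrogen on an aromatic carbon. Among the compounds with values here, no pair of measured compounds differs by exactly this change, so the size of the step is not known from the data. The same ring substitution pattern is present in compound 1 with the other core, and for compound 1 this assay returned only the limit > 100000 nM. Expectation is therefore no step beyond the scatter, most likely a result at or near the limit again, with the step from compound 3 to compound 4 expected as a number no higher from compound 3 to compound 4 (the limit leaves the size open). For compound 4 the estimate in this assay is 100000 nM, expected to fall between 40000 nM and 300000 nM.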

Compound 4, concentration for total growth inhibition: > 100000 nM
Compound 4: a limit, no number; the forecaster's own chance of this, stated with the estimate: 70%; the middle value sits exactly at the limit.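

Compound 3 and compound 4 both return only limits in this assay, so no step can be read between them. The compounds shown leave open what methoxy in place of hydrogen on an aromatic carbon does to growth inhibition on this core, and how far past the limit compound 3 and compound 4 lie.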